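Chloro to methyl on the sulfonyl ring of compound 1

The source may hold more compounds than are shown below. What is called first, only, known or untested is meant among the compounds shown, and "the series" means these compounds.

Compound 1 `CCCCC(CC)C(=O)Nc1ccc2ccn(Cc3ccc(C(=O)NS(=O)(=O)c4ccc(Cl)cc4)cc3OC)c2c1` is measured in a functional assay (trachea) for antagonist activity, with Cavia porcellus as the target (a higher number here means a more potent compound, by a factor of ten per unit of this negative logarithm, a lower number a less potent compound), and gives 7.8. Compound 2 `COc1cc(-c2nn[nH]n2)ccc1Cn1ncc2ccc(NC(=O)OC3CCCC3)cc21` gives 7.7 in this assay, and the two numbers lie within the scatter of each other, so nothing separates them. Compound 3 `CCCCC(CC)C(=O)Nc1ccc2ccn(Cc3ccc(C(=O)NS(=O)(=O)c4ccc(C)cc4)cc3OC)c2c1` is not yet measured; it differs from compound 1 by methyl in place of chloro on an aromatic carbon. Among the compounds with values here, no measured pair shows this change, so any expectation rests on compound 1 alone. The step of a number 0.20 log units lower from compound 1 to compound 3 (within the scatter) is expected to stay within the scatter, if anything slightly downward. Compound 3 is estimated at 7.6, with a range from 7.1 to 8.1.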

Compound 3, negative logarithm of the antagonist equilibrium constant: 8.4
Compound 3: middle estimate off by 0.80 log units, on the low side, and the stated range ends below it.
By their numbers in this assay, from the lowest: compounds 2 and 1 (each within the scatter of the next); then compound 3.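

The sulfonyl ring's para substituent is not a silent position: methyl in place of chloro gives a number 0.60 log units higher from compound 1 to compound 3 (beyond the scatter) in this assay, with the heavy-atom count unchanged. Within the data shown here, this is the first step beyond the scatter, and a single-atom exchange on the 4-chlorophenyl group is enough to produce it. Nothing measured on these compounds accounts for the step.

Going by these compounds, whether ethyl, methoxy or a plain hydrogen at this place would match or exceed methyl remains open. One pair also cannot show whether the step would hold with a different acyl chain on the shared core.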